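Bromomethyl in place of propoxycarbonyl: expectation for compound 4

The source may report more compounds than this note shows. Statements on the series, on what has been measured and on what is new or still open speak of the compounds shown alone.

Compound 1 `CCCOC(=O)c1c(C)coc1-c1ccc2c(CC)cccc2c1OC` is the reference point. In a functional assay on KBVIN cells (Homo sapiens) for cytotoxicity, read by MTT assay, with a stated time of 72 h (on this read-out lower numbers stand for an effect already at smaller amounts and higher numbers for an effect only at larger amounts of compound), compound 1 gives > 10 ug/mL, which is a limit of the assay and not a number. Compound 2 `CCc1cccc2c(OC)c(-c3occ(C)c3C(=O)On3nnc4ccccc43)ccc12` gives > 10 ug/mL in this assay, again only a limit. Compound 3 `CCOc1c(-c2occ(C)c2C(=O)OC)ccc2c(CC)cccc12` gives 1.7 ug/mL in this assay. Going by the values given here, the only counted step, from compound 1 to compound 2, is a step that the two limits leave unreadable from compound 1 to compound 2; its size stays hidden since both values sit at the limit of > 10 ug/mL in this assay, at which 2 of the 3 values shown sit. Compound 3 differs from compound 1 in two places, so its value stands beside that of compound 1 without a counted step. Compound 4 `CCc1cccc2c(OC)c(-c3occ(C)c3CBr)ccc12` differs from compound 1 thus: bromomethyl in place of propoxycarbonyl on an aromatic carbon. Among the compounds with values here, none of the measured steps touches this position or this pair of groups, so no measured step bears on the change, and its size cannot be read from the present data. The step from compound 1 to compound 4 is nonetheless expected as an at least 3.3-fold lower number from compound 1 to compound 4 (0.52 log units; beyond the scatter), toward an effect at smaller amounts. Compound 4 is expected to give about 3 ug/mL, within 0.8 ug/mL to 10 ug/mL.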

Compound 4, concentration for half-maximal effect: > 10 ug/mL
Compound 4: a limit, no number (the forecaster's own chance of this, stated with the estimate: 25%); middle value at least 3.3-fold (0.52 log units) from the limit.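

In this assay compound 4 gives > 10 ug/mL as a limit and not a number. With compound 1 also at a limit, no step can be read between compound 1 and compound 4: the limit of > 10 ug/mL in this assay, at which 3 of the 4 values shown sit. From the compounds shown here alone, the size and direction of the change from propoxycarbonyl to bromomethyl on the shared core remain open.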